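Swapping Methoxy for Chloro on Compound 3

This account rests on a few compounds, and the source may have more. Where it says the series, first, only, none or still open, it means among the compounds named here.

Measured in a functional assay on A549 cells (Homo sapiens) for antiproliferative activity, read by MTT assay, with a stated time of 72 h; a lower number here means a stronger inhibitor, a higher number a weaker inhibitor:
- compound 1 `COc1ncc(-c2ccc3c(c2)NC(=O)CO3)cc1NS(=O)(=O)c1ccc(F)cc1`: 8070 nM
- compound 2 `COc1ncc(-c2ccc3c(c2)N(C2CC2)C(=O)CO3)cc1NS(=O)(=O)c1ccc(F)cc1`: 3320 nM
- compound 3 `COc1ccc(N2C(=O)COc3ccc(-c4cnc(OC)c(NS(=O)(=O)c5ccc(F)cc5)c4)cc32)cc1`: 1350 nM

Among these three, compound 3 has the lowest number, 1350 nM, which makes it the most potent so far. Its gaps to the other two lie beyond the scatter: a 6.0-fold lower number from compound 1 to compound 3 (0.78 log units; beyond the scatter) and a 2.5-fold lower number from compound 2 to compound 3 (0.39 log units; beyond the scatter).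

Compound 4 `COc1ncc(-c2ccc3c(c2)N(c2ccc(Cl)cc2)C(=O)CO3)cc1NS(=O)(=O)c1ccc(F)cc1` keeps all of compound 3 except one group. It has chloro in place of methoxy on an aromatic carbon, para to a large group, so 4-methoxyphenyl becomes 4-chlorophenyl (chloro in place of methoxy on an aromatic carbon).

Among the compounds with values here, no measured pair tests this exact swap. The nearest evidence comes from changes to the whole group on the same ring nitrogen, and even those were modest: a 6.0-fold lower number from compound 1 to compound 3 (0.78 log units; beyond the scatter), a 2.5-fold lower number from compound 2 to compound 3 (0.39 log units; beyond the scatter) and a 2.4-fold lower number from compound 1 to compound 2 (0.39 log units; beyond the scatter). Compound 4 keeps the phenyl ring and changes only its substituent, so a smaller change is expected, with no shift beyond the scatter in this assay.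

The expected step is a 1.1-fold lower number from compound 3 to compound 4 (0.05 log units; within the scatter).

For compound 4 the estimated value is 1200 nM, with an expected range of 500 nM to 2900 nM.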

Compound 4, half-maximal inhibitory concentration: 8350 nM
Beside the measured number, compound 4's estimate is 7.0-fold (0.84 log units) below it, and the stated range ends below it.
By their numbers in this assay, from the lowest: compound 3; then compound 2; then compounds 1 and 4 (each within the scatter of the next).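

In this assay, a single substituent on the outer phenyl ring counts for much: the swap gives a 6.2-fold higher number from compound 3 to compound 4 (0.79 log units; beyond the scatter) and is about as large as the whole-group step of a 6.0-fold lower number from compound 1 to compound 3 (0.78 log units; beyond the scatter). Replacing cyclopropyl with 4-chlorophenyl gives a 2.5-fold higher number from compound 2 to compound 4 (0.40 log units; beyond the scatter) and replacing the amide hydrogen with it gives a 1.0-fold higher number from compound 1 to compound 4 (0.01 log units; within the scatter) so among these compounds the lower number goes with 4-methoxyphenyl, not with just any phenyl ring on this nitrogen. No measurement shown here explains why methoxy and chloro differ so strongly at this place.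

The compounds shown leave open whether the rise follows the loss of methoxy or the arrival of chloro, with only these two substituents on this carbon. A hydroxyl, a methyl or a dimethylamino group at the same place would help to separate those two readings.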